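Benzyl to phenyl on the amine of a nitropyrimidine

The compounds below may be only part of what the source reports. "The series", "measured", "known", "first", "only" and "open" are said of these compounds alone.

Measured compounds:
- compound 1, `CCOC(=O)CN(Cc1ccccc1)c1nc(NCc2cccc(OC)c2)ncc1[N+](=O)[O-]`, with 33600 nM in a functional assay on HepG2 cells (Homo sapiens) for antiproliferative activity, read by MTT assay, with a stated time of 48 h; a lower number here means a stronger inhibitor, a higher number a weaker inhibitor
- compound 2, `COC(=O)CN(C)c1nc(NCc2ccccc2)ncc1[N+](=O)[O-]`, with > 100000 nM in this assay

In this assay compound 1 gives 33600 nM. For compound 2 the result is a limit of the assay and not a number: > 100000 nM. Among the compounds with values here, this is the limit of > 100000 nM in this assay, at which 1 of the 2 values shown sits, so compound 2 stands at the edge of what the assay can report, and no step between compound 1 and compound 2 is computed, since the two differ in more than one place.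

Compound 3, `COC(=O)CN(C)c1nc(Nc2ccccc2)ncc1[N+](=O)[O-]`, is not yet measured. It differs from compound 2 by phenyl in place of benzyl on a nitrogen on an aromatic ring. No measured pair shows this change, so the size of the step is unknown from the data shown. Given that compound 2 already sits at the limit with > 100000 nM, the expected step from compound 2 to compound 3 is a step that the limit leaves unreadable from compound 2 to compound 3, which means no movement beyond the scatter that can be resolved from a limit. For compound 3 the expected value in this assay is 120000 nM, with a range from 40000 nM to 400000 nM, and a report of only a limit is considered likely.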

Compound 3, half-maximal inhibitory concentration: > 100000 nM
Compound 3: no number, only a limit (the forecaster's own chance of this, stated with the estimate: 75%); the middle value lies beyond the limit too.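

In this assay compound 3 gives > 100000 nM and this is a limit, not a number. Compound 2 also gives only a limit, so no step can be read from compound 2 to compound 3, with both at the edge of the assay: the limit of > 100000 nM in this assay, at which 2 of the 3 values shown sit. The compounds shown leave open whether phenyl in place of benzyl matters where a number can be read.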